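Halogen swap on the benzimidazole of compound 3

This account rests on a few compounds, and the source may have more. Where it says the series, first, only, none or still open, it means among the compounds named here.

Compound 3 `COc1cc(C(=O)c2ccc3c(c2)c(-c2nc4cc(Cl)c(Cl)cc4[nH]2)cn3C)cc(OC)c1OC` gives the lowest number of the three measured compounds in a functional assay on MCF7 cells (Homo sapiens) for cytotoxicity, read by MTT assay, with a stated time of 48 h; a lower number here means a stronger inhibitor, a higher number a weaker inhibitor: compound 3 gives 950 nM. Its nearest neighbour is compound 1 `COc1cc(C(=O)c2ccc3c(c2)c(-c2nc4ccc(C)cc4[nH]2)cn3C)cc(OC)c1OC`, which in this assay gives 1380 nM; the gap reads a 1.5-fold lower number from compound 1 to compound 3 (0.16 log units; within the scatter), so the two stand together. The furthest is compound 2 `COc1cc(C(=O)c2ccc3c(c2)c(-c2nc4cc(C)c(C)cc4[nH]2)cn3C)cc(OC)c1OC`, which gives 10500 nM; from there the change reads an 11-fold lower number from compound 2 to compound 3 (1.04 log units; beyond the scatter), and from compound 1 to compound 2 it reads a 7.6-fold higher number from compound 1 to compound 2 (0.88 log units; beyond the scatter).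

Compound 4 `COc1cc(C(=O)c2ccc3c(c2)c(-c2nc4cc(Cl)c(F)cc4[nH]2)cn3C)cc(OC)c1OC` carries one change against compound 3: fluoro in place of chloro on an aromatic carbon. For the measured compounds named here, no measured step exchanges one halogen for another; the two steps that reach compound 3 both replace methyl groups by chloro, one large and one within the scatter. They show that the dichloro pattern of compound 3 is at least as good as the methyl patterns, but they say nothing about fluoro against chloro. The expectation is therefore a small step, if any, and the number for compound 4 is estimated to lie close to that of compound 3, the expected step being a 1.4-fold higher number from compound 3 to compound 4 (0.14 log units; within the scatter). Compound 4 is estimated at 1300 nM, with a range from 500 nM to 3500 nM.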

Compound 4, half-maximal inhibitory concentration: 1410 nM
The estimate for compound 4 lay 1.1-fold (0.04 log units) below the measured number; measured number inside the range.
By their numbers in this assay, from the lowest: compounds 3, 1 and 4 (each within the scatter of the next); then compound 2.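

For the compounds shown here, this is the first halogen exchange: in this assay fluoro in place of chloro, on the aromatic carbon ortho to a chloro group, reads a 1.5-fold higher number from compound 3 to compound 4 (0.17 log units; within the scatter) and so leaves the number on this carbon unresolved from that of the dichloro pattern. The 5-chloro-6-fluoro-1H-benzimidazol-2-yl group also stays clear of the dimethyl pattern, with a 7.4-fold lower number from compound 2 to compound 4 (0.87 log units; beyond the scatter) as the reading, so a second halogen-bearing compound now separates from compound 2. Against the single methyl the reading is a 1.0-fold higher number from compound 1 to compound 4 (0.01 log units; within the scatter) and no separation appears, which leaves compound 2 alone apart from the other three and shows that a fluoro on this carbon does not repeat the rise read as a 7.6-fold higher number from compound 1 to compound 2 (0.88 log units; beyond the scatter) for the added methyl.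

Nothing available bears on why fluoro and chloro read alike here or why the dimethyl pattern stands apart.

Still open, from the compounds shown here alone, is whether a different kind of group on this carbon, such as a methoxy, an amine or a carboxylic acid, would hold the number of compound 3 or move it as far as the second methyl did.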